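A few compounds are considered here, and "the series" means these few. Any claim that something is new, unique, unknown or untested is made for them only; others in the source may bear on it.

Measured in a functional assay on K562 cells (Homo sapiens) for inhibition, read by trypan blue exclusion, with a stated time of 72 h; on this read-out lower numbers stand for stronger inhibition and higher numbers for weaker inhibition:
- Compound 1 `COc1ccc(Nc2ncc3cc(S(=O)(=O)c4ccc(C)cc4)c(=O)n(C)c3n2)cc1`: 75000 nM
- Compound 2 `COc1ccc(S(=O)(=O)c2cc3cnc(Nc4ccc5[nH]ccc5c4)nc3n(C)c2=O)cc1`: 300 nM
- Compound 3 `Cn1c(=O)c(S(=O)(=O)c2ccc(F)cc2F)cc2cnc(Nc3ccc4c(c3)CC(=O)N4)nc21`: 15000 nM

Of these three numbers, that of compound 3 is the second highest, with the gaps to compound 1 and compound 2 both beyond the scatter. Compound 4 `Cn1c(=O)c(S(=O)(=O)c2ccc(F)cc2F)cc2cnc(Nc3ccc4cc[nH]c4c3)nc21` differs from compound 3 in one place: a group of 9 heavy atoms (8 carbon, 1 nitrogen; one five-membered aromatic ring with 1 hetero atom, one six-membered aromatic ring of carbon only) in place of a group of 10 heavy atoms (8 carbon, 1 nitrogen, 1 oxygen; one five-membered non-aromatic ring with 1 hetero atom, one six-membered aromatic ring of carbon only), on a nitrogen on an aromatic ring. For the measured compounds named here, no measured pair isolates this change. Compound 2 also carries a group with a five-membered aromatic ring with 1 hetero atom on a nitrogen on an aromatic ring, and it gives 300 nM, though it differs from compound 4 elsewhere too. A drop beyond the scatter is therefore expected in this assay, estimated as a 10-fold lower number from compound 3 to compound 4 (1.00 log units; beyond the scatter). The expected value for compound 4 is 1500 nM, within an estimated range of 300 nM to 8000 nM.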

Compound 4, half-maximal inhibitory concentration: 5000 nM
Compound 4: the middle estimate sits 3.3-fold (0.52 log units) below what was measured, and the stated range covers the measured number.
By their numbers in this assay, from the lowest: compound 2; then compound 4; then compound 3; then compound 1.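

For the compounds shown here, this pair is the first to isolate a change at this place, on a nitrogen on an aromatic ring: in this assay, 1H-indol-6-yl in place of the group with the five-membered non-aromatic ring gives a 3.0-fold lower number from compound 3 to compound 4 (0.48 log units; beyond the scatter), a modest step beyond the scatter. The lower number comes with the hydrogen-bond acceptor of the leaving group gone and the hydrogen-bond donor count unchanged. Nothing measured here explains the step. The compounds shown leave open how an amine or a carboxylic acid on the 1H-indol-6-yl group would read, and whether this change gives a similar step with a methoxyphenyl group on the sulfonyl.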